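The source may report more compounds than this note shows. Statements on the series, on what has been measured and on what is new or still open speak of the compounds shown alone.

Compound 1 `COc1ccccc1N1C(=O)CSC1c1cccc(C(=O)NCCCCc2ccc(Cl)cc2)c1`: 78.6 nM
Compound 2 `CCN(CC)c1ccc(N2C(=O)CSC2c2cccc(C(=O)NCCCCc3ccccc3)c2)cc1`: > 1000 nM (a limit, not a number)
Compound 3 `Cc1cccc(N2C(=O)CSC2c2cccc(C(=O)NCCCCc3ccccc3)c2)c1`: 93.2 nM

In a functional assay on HOS-TE85 cells (Homo sapiens) for inhibition, read by CCK-8 assay, with a stated time of 72 h (a higher number here means a weaker inhibitor, a lower number a stronger inhibitor), compound 1 gives 78.6 nM, within the scatter of compound 3 at 93.2 nM. Compound 4 `COc1ccccc1N1C(=O)CSC1c1cccc(C(=O)NCCCCn2cccn2)c1` keeps the rest of compound 1 and changes one group: 1H-pyrazol-1-yl in place of 4-chlorophenyl on a saturated chain carbon, four bonds along the chain from an amide-type nitrogen. For the measured compounds named here, the only measured step, an at least 10-fold lower number from compound 2 to compound 3 (1.03 log units; beyond the scatter), has 3-methylphenyl in place of 4-(diethylamino)phenyl on an amide-type nitrogen in a ring. Going by the values given here, it is large, but it lies elsewhere, and no measured step tests the new group. Compound 1 and compound 3 both carry a carbon-only aromatic ring on the chain, so losing that ring makes a moderate weakening the likeliest outcome. The estimate is a 3.8-fold higher number from compound 1 to compound 4 (0.58 log units; beyond the scatter), a moderately higher number. For compound 4 the expected value is 300 nM, with an estimated range of 70 nM to 1300 nM.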

Compound 4, half-maximal inhibitory concentration: 91.7 nM
Compound 4: middle estimate off by 3.3-fold (0.51 log units), on the high side; the range from low to high includes it.
By their numbers in this assay, from the lowest: compounds 1, 4 and 3 (each within the scatter of the next). At a limit, above all of these: compound 2.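

At this position, on a saturated chain carbon, four bonds along the chain from an amide-type nitrogen, 1H-pyrazol-1-yl in place of 4-chlorophenyl gives a 1.2-fold higher number from compound 1 to compound 4 (0.07 log units; within the scatter) in this assay. In this one pair, then, a six-membered aromatic ring of carbon only is not required, and a five-membered aromatic ring with 2 hetero atoms does as well. Nothing in the data shown explains this result.

From the compounds shown here alone, whether the chain end needs an aromatic ring at all stays open. An amine or a carboxylic acid in that place, or a longer chain, would address this.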